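This account rests on a few compounds, and the source may have more. Where it says the series, first, only, none or still open, it means among the compounds named here.

Compound 3, `CC(=O)N(C)CC#CCn1ccnc1`, is the only one of the three measured compounds that gives a number in a functional assay on the whole organism for agonist activity, with Mus musculus as the target; on this read-out lower numbers stand for an effect already at smaller amounts and higher numbers for an effect only at larger amounts of compound: compound 3 gives 1.4 mg/kg. Compound 1, `CC1CCC(=O)N1CC#CCn1ccnc1`, carries a different core. Compound 1 reaches only the limit of the assay in this assay, where it gives > 100 mg/kg. Compound 2, `Cc1cncn1CC#CCN1C(=O)CCC1C`, arises from compound 1 by methyl in place of hydrogen on an aromatic carbon. Compound 2 also reaches only the limit in this assay, where it gives > 100 mg/kg. The step that the two limits leave unreadable from compound 1 to compound 2 therefore cannot be sized, a consequence of the limit of > 100 mg/kg in this assay, at which 2 of the 3 values shown sit. How the cores of compound 3 and compound 1 differ is not broken down here.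

Compound 4, `CC(=O)N(C)CC#CCn1cncc1C`, is the unmeasured partner of compound 3. The difference between compound 3 and compound 4 is methyl in place of hydrogen on an aromatic carbon. Among the compounds with values here, this is the same kind of change as the one from compound 1 to compound 2; the two places are described differently only in that the ring atom next to the changed carbon bears a group of 9 heavy atoms in compound 3 and a large group in compound 1. The earlier instance of the change, from compound 1 to compound 2, could not be sized. The size of this step in this assay is therefore expected only loosely, as a 1.8-fold higher number from compound 3 to compound 4 (0.25 log units; within the scatter). This expectation rests on the value of compound 3, 1.4 mg/kg, and on nothing that sizes the methyl change itself. For compound 4 the expected dose in this assay is 2.5 mg/kg, within 0.7 mg/kg to 15 mg/kg.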

Compound 4, dose for half-maximal effect: 45 mg/kg
For compound 4 the middle estimate is 18-fold (1.26 log units) below the measured one, and the stated range ends below it.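

In this assay, methyl in place of hydrogen on an aromatic carbon gives a 32-fold higher number from compound 3 to compound 4 (1.51 log units; beyond the scatter), so on the core of compound 3 this single added carbon is a large step. The same change on the core of compound 1 cannot be read, and the series therefore gives no size for it on a second core: the limit of > 100 mg/kg in this assay, at which 2 of the 4 values shown sit. What the result shows is the size of the methyl step on one core only; it does not show that this size carries over from one core to another, nor that it fails to, since compound 1 and compound 2 both stand at a limit and offer nothing to set beside it.

The compounds shown leave open whether the large step belongs to methyl itself or would also follow another group at the same aromatic carbon, such as ethyl or chlorine, neither of which is among them. They also leave open whether a compound on the core of compound 1 that gave a readable number would show a methyl step of similar size.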